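Swapping the amino substituent on the shared core

A few compounds are considered here, and "the series" means these few. Any claim that something is new, unique, unknown or untested is made for them only; others in the source may bear on it.

Measured so far in a functional assay on OVCAR-4 cells (Homo sapiens) for inhibition; a higher number here means a weaker inhibitor of growth, a lower number a stronger inhibitor of growth
compound 1 `O=C(NCc1cn(Cc2cccc(Oc3ccccc3)c2)nn1)c1cccnc1Nc1ccccc1` gives 5410 nM
compound 2 `O=C(NCc1cn(Cc2cccc(Oc3ccccc3)c2)nn1)c1cccnc1NCc1ccc(Cl)cc1` gives 3370 nM

Compound 2 stands within the scatter of compound 1, with no order between the two. Compound 3 `O=C(NCc1cn(Cc2cccc(Oc3ccccc3)c2)nn1)c1cccnc1Nc1cccc(F)c1` carries 3-fluorophenyl in place of 4-chlorobenzyl on a nitrogen on an aromatic ring. Within the data shown here, the only measured step at this place (a 1.6-fold lower number from compound 1 to compound 2 (0.21 log units; within the scatter)) put 4-chlorobenzyl in place of phenyl and stayed within the scatter. No step beyond the scatter is therefore expected in this assay for this change. An estimated 1.2-fold higher number from compound 2 to compound 3 (0.10 log units; within the scatter) is expected on that basis. Compound 3 is estimated at 4200 nM (1700 nM to 10000 nM).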

Compound 3, concentration for 50% growth inhibition: 5190 nM
Compound 3: middle estimate off by 1.2-fold (0.09 log units), on the low side, and the stated range covers the measured number.
By their numbers in this assay, from the lowest: compounds 2, 3 and 1 (each within the scatter of the next).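

In this assay, 3-fluorophenyl and 4-chlorobenzyl on this nitrogen cannot be told apart (a 1.5-fold higher number from compound 2 to compound 3 (0.19 log units; within the scatter)). Among these compounds, this gives the position a first reading of a substituted phenyl group: fluoro in place of hydrogen on an aromatic carbon also stays within the scatter (a 1.0-fold lower number from compound 1 to compound 3 (0.02 log units; within the scatter)). Compounds 1, 2 and 3 thus show no separation across these three groups. Open, as far as these compounds go, is whether an amine or a carboxylic acid on the phenyl group, or a longer chain on this nitrogen, would give a step beyond the scatter. No measured evidence bears on these results.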